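This account rests on a few compounds, and the source may have more. Where it says the series, first, only, none or still open, it means among the compounds named here.

Values in a functional assay on A549 cells (Homo sapiens) for antiproliferative activity, read by MTT assay, with a stated time of 48 h; a higher number here means a weaker inhibitor, a lower number a stronger inhibitor:
Compound 1 `COc1ccc(/C=C/c2cc(OC)cc(OC)c2/C=C/C(=O)c2ccc(Cl)c(Cl)c2)cc1`: 5.9 ug/mL
Compound 2 `COc1ccc(/C=C/c2cc(OC)cc(OC)c2/C=C/C(=O)c2ccc(C)cc2)cc1`: 3.6 ug/mL
Compound 3 `COc1ccc(/C=C/c2cc(OC)cc(OC)c2/C=C/C(=O)c2cccc(Cl)c2)cc1`: 5.6 ug/mL

The three compounds share one core and differ only in the aromatic group on the carbonyl carbon. Compound 3 gives 5.6 ug/mL, a value that sits within the scatter of the other two. The two steps that reach it are a 1.1-fold lower number from compound 1 to compound 3 (0.02 log units; within the scatter) and a 1.6-fold higher number from compound 2 to compound 3 (0.19 log units; within the scatter).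

Compound 4 `COc1ccc(/C=C/c2cc(OC)cc(OC)c2/C=C/C(=O)c2ccc(N)cc2)cc1` has not yet been measured. It differs from compound 3 in one place: 4-aminophenyl in place of 3-chlorophenyl on a carbonyl carbon. In words, this is 4-aminophenyl in place of 3-chlorophenyl on a carbonyl carbon.

Among the measured compounds shown here, all the measured steps change the group at this same place, so they are the closest guide. The remaining one is a 1.6-fold lower number from compound 1 to compound 2 (0.21 log units; within the scatter), and like the other two it stays inside the scatter. That flat picture covers only these three compounds, and none of them carries a 4-aminophenyl group, so the data leave some room for surprise. No shift beyond the scatter is expected, in either direction. The expected step is a 1.2-fold lower number from compound 3 to compound 4 (0.09 log units; within the scatter). For compound 4 the estimated value is 4.5 ug/mL, with an expected range of 2 ug/mL to 9.5 ug/mL.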

Compound 4, half-maximal inhibitory concentration: 3.8 ug/mL
For compound 4 the middle estimate is 1.2-fold (0.07 log units) above the measured one, and the stated range covers the measured number.
By their numbers in this assay, from the lowest: compounds 2, 4, 3 and 1 (each within the scatter of the next).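

The new group differs in kind from the one it replaces: the entering 4-aminophenyl counts a hydrogen-bond donor and a hydrogen-bond acceptor, where the leaving 3-chlorophenyl counts neither, yet in this assay this change gives only a small step (a 1.5-fold lower number from compound 3 to compound 4 (0.17 log units; within the scatter)), and the change from 3,4-dichlorophenyl stays equally small (a 1.6-fold lower number from compound 1 to compound 4 (0.19 log units; within the scatter)). Amino in place of methyl on the same aromatic carbon also leaves the number within the scatter (a 1.1-fold higher number from compound 2 to compound 4 (0.02 log units; within the scatter)), so this assay does not separate these two groups, and the flat picture at this position now extends to a nitrogen-bearing group as well as to the chloro and methyl ones. No measured evidence is available that could explain this flatness.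

Since every step among these four compounds stays within the scatter, they do not show whether any group on this carbonyl carbon can move the number beyond it. A phenyl ring carrying a carboxylic acid, or a longer chain in place of the aromatic ring, would test that limit, and the compounds shown say nothing about either.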